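Removing the methyl from the ether oxygen of compound 3

A few compounds are considered here, and "the series" means these few. Any claim that something is new, unique, unknown or untested is made for them only; others in the source may bear on it.

Among the three measured compounds, compound 3 `COc1cc(-c2cccnc2)ccc1C(N)=O` holds the second highest number in an assay on cells for inhibition of MAP kinase-interacting serine/threonine-protein kinase 1 (Homo sapiens), read by mobility shift assay, with stated times of 10 min and 60 min, in the presence of a further agent that is not named here; on this read-out higher numbers stand for weaker inhibition and lower numbers for stronger inhibition; compound 3 gives 2800 nM. Compound 1 `NC(=O)c1ccc(-c2cccnc2)cc1OC1CCNCC1` gives 1100 nM, and compound 2 `CCNc1cc(-c2cccnc2)ccc1C(N)=O` gives 58000 nM. The measured steps are a 2.5-fold higher number from compound 1 to compound 3 (0.41 log units; beyond the scatter), a 21-fold lower number from compound 2 to compound 3 (1.32 log units; beyond the scatter) and a 53-fold higher number from compound 1 to compound 2 (1.72 log units; beyond the scatter).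

Compound 4 `NC(=O)c1ccc(-c2cccnc2)cc1O` is compound 3 with hydrogen in place of methyl on an oxygen on an aromatic ring. Of the measured steps, only a 2.5-fold higher number from compound 1 to compound 3 (0.41 log units; beyond the scatter) changes the group on this oxygen, and there the smaller group brought the higher number. The other two steps exchange the whole group on the aromatic carbon and bear only loosely on the present change. Taking the group on the oxygen down to hydrogen is therefore expected to move the number in the same direction as the step from compound 1 to compound 3, by a modest amount: the expected step is a 2.1-fold higher number from compound 3 to compound 4 (0.33 log units; beyond the scatter). Compound 4 is expected to give 6000 nM, within a range of 2000 nM to 18000 nM.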

Compound 4, half-maximal inhibitory concentration: 4300 nM
The estimate for compound 4 lay 1.4-fold (0.14 log units) above the measured number; the measured number falls inside the stated range.
By their numbers in this assay, from the lowest: compound 1; then compounds 3 and 4 (each within the scatter of the next); then compound 2.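

In this assay, for the compounds shown here, the change from methoxy to hydroxy gives a 1.5-fold higher number from compound 3 to compound 4 (0.19 log units; within the scatter) and so stays within the scatter, which shows that the methyl on this oxygen can go without a measurable change, something the earlier compounds could not show. The hydroxy compound also gives a 13-fold lower number from compound 2 to compound 4 (1.13 log units; beyond the scatter) and a 3.9-fold higher number from compound 1 to compound 4 (0.59 log units; beyond the scatter) as its two remaining steps, so the wide gap to the ethylamino compound holds for hydroxy as for methoxy, while (piperidin-4-yl)oxy stays clear of both smaller groups on this oxygen. No supporting measurement bears on these steps.

Open, from the compounds shown here alone, is whether the lower number of compound 1 needs the ring or only an amine, which a 2-aminoethyl chain on this oxygen would test. Also open, going by these compounds, is how a primary amine on the aromatic carbon would compare with ethylamino.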